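A few compounds are considered here, and "the series" means these few. Any claim that something is new, unique, unknown or untested is made for them only; others in the source may bear on it.

The measured compounds in an assay on CHO cells for displacement of a labelled ligand from adenosine receptor A1 (Homo sapiens), read by scintillation counting, with a stated time of 90 min, in the presence of a further agent that is not named here; on this read-out higher numbers stand for weaker inhibition and lower numbers for stronger inhibition:

Compound 1 `CCCn1c(=O)c2[nH]c(-c3ccc(S(=O)(=O)N4CCN(c5ccc(Cl)cc5)CC4)cc3)nc2n(C)c1=O` gives > 1000 nM, which is a limit of the assay and not a number.
Compound 2 `CCCn1c(=O)[nH]c2nc(-c3ccc(S(=O)(=O)N4CCN(c5ccccc5)C(C)C4)cc3)[nH]c2c1=O` gives > 1000 nM, again a limit rather than a number.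
Compound 3 `CCCn1c(=O)[nH]c2nc(-c3ccc(S(=O)(=O)N4CCN(c5ccccc5)CC4)cc3)[nH]c2c1=O` gives 364 nM.

Among the compounds with values here, compound 3 therefore stands as the only compound with a measured number; the other two sit at the limit of > 1000 nM in this assay, at which 2 of the 3 values shown sit. Within the data shown here, the one measured step, an at least 2.7-fold lower number from compound 2 to compound 3 (0.43 log units; beyond the scatter), hydrogen in place of methyl on a saturated ring carbon, is the only change with a size attached to it.

Compound 4 `CCCn1c(=O)[nH]c2nc(-c3ccc(S(=O)(=O)N4CCN(Cc5ccc(Br)c(F)c5)CC4)cc3)[nH]c2c1=O` differs from compound 3 by 4-bromo-3-fluorobenzyl in place of phenyl on an amine nitrogen in a ring. Among the measured compounds shown here, no measured step bears on this kind of exchange: the one step above concerns a saturated ring carbon and says nothing about what is attached to the amine nitrogen in a ring. For the measured compounds named here, with no comparable step to lean on, the expectation rests on compound 3 alone and carries wide uncertainty, and no step beyond the scatter is expected in either direction. The expected change is a 1.4-fold higher number from compound 3 to compound 4 (0.14 log units; within the scatter). Compound 4 is estimated to give 500 nM, with a range from 150 nM to 1500 nM.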

Compound 4, inhibition constant: 326 nM
For compound 4 the middle estimate is 1.5-fold (0.19 log units) above the measured one, within the range that was stated.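

In this assay, putting 4-bromo-3-fluorobenzyl in place of phenyl gives a 1.1-fold lower number from compound 3 to compound 4 (0.05 log units; within the scatter). Within the data shown here, this is the first measured change on the amine nitrogen in a ring, and it shows that a larger group carrying bromine and fluorine can stand there with no shift beyond the scatter, unlike the earlier exchange on a saturated ring carbon. Nothing measured here explains why the number holds across this exchange.

The extra carbon, the bromine and the fluorine all arrive together in this one exchange, so their separate contributions cannot be told apart. From the compounds shown here alone, whether a plain benzyl, or a group bearing an amine or a carboxylic acid, would fare the same on this nitrogen remains open.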